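A few compounds are considered here, and "the series" means these few. Any claim that something is new, unique, unknown or untested is made for them only; others in the source may bear on it.

Measured so far in a functional assay on SW480 cells (Homo sapiens) for antiproliferative activity, read by sulforhodamine B assay, with a stated time of 48 h; on this read-out lower numbers stand for stronger inhibition and higher numbers for weaker inhibition:
- compound 1 `COc1ccc(/C=C/C(=O)c2ccccc2-c2ccc(F)cc2)cc1`: 61 nM
- compound 2 `CN(C)c1ccc(/C=C/C(=O)c2ccccc2-c2ccc(F)cc2)cc1`: 41 nM

Among the measured compounds shown here, with only two compounds measured, compound 1 has a single neighbour, compound 2, and the two cannot be told apart: the one measured step is a 1.5-fold lower number from compound 1 to compound 2 (0.17 log units; within the scatter). That step puts dimethylamino in place of methoxy on an aromatic carbon, and the ring carrying the group stays.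

Compound 3 `Cc1ccc(/C=C/C(=O)c2ccccc2-c2ccc(F)cc2)o1` goes further, with 5-methylfuran-2-yl in place of 4-methoxyphenyl on a double-bonded chain carbon bound to a double-bonded chain carbon. For the measured compounds named here, no measured pair shows what exchanging the whole ring does, so the step from compound 1 to compound 2, at a 1.5-fold lower number from compound 1 to compound 2 (0.17 log units; within the scatter), offers only a loose guide. It shows that one change to the group on that ring stayed within the scatter, but it says little about losing the ring itself. A modest move towards a higher number is therefore expected, with real uncertainty about both size and direction. The expected step in this assay is a 2.5-fold higher number from compound 1 to compound 3 (0.39 log units; beyond the scatter). For compound 3 the estimated value is 150 nM, with an expected range from 30 nM to 750 nM.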

Compound 3, half-maximal inhibitory concentration: 23000 nM
Beside the measured number, compound 3's estimate is 150-fold (2.19 log units) below it; the measured number lies above the stated range.
By their numbers in this assay, from the lowest: compounds 2 and 1 (each within the scatter of the next); then compound 3.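

In this assay, the group on this double-bonded chain carbon proves far less forgiving than the earlier pair suggested. Exchanging the whole ring, 5-methylfuran-2-yl in place of 4-methoxyphenyl, gives (a 380-fold higher number from compound 1 to compound 3 (2.58 log units; beyond the scatter)), whereas changing only the group on the ring gave (a 1.5-fold lower number from compound 1 to compound 2 (0.17 log units; within the scatter)), so this position tolerates one kind of change but not the other, at least across these three compounds. The exchange swaps a six-membered aromatic ring of carbon only for a five-membered aromatic ring with 1 hetero atom, while the counts of hydrogen-bond donors and acceptors and the absence of net charge stay the same, and nothing available here accounts for the large step.

The compounds shown leave open which part of the exchange carries the step: the smaller ring, its ring oxygen, or the methyl in place of the methoxy group. A plain phenyl group, an unsubstituted furan-2-yl group or a 5-methylthiophen-2-yl group on the same chain carbon would help to separate these possibilities.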